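Working notes: methyl to amino, compounds 1 to 4

A few compounds are considered here, and "the series" means these few. Any claim that something is new, unique, unknown or untested is made for them only; others in the source may bear on it.

Compound 1, `Nc1nc(N)c2c(-c3ccccc3)cn([C@@H]3O[C@H](CO)[C@@H](O)[C@H]3O)c2n1`, in a functional assay on HL-60 cells (Homo sapiens) for antiproliferative activity, read by XTT assay, with a stated time of 72 h (on this read-out lower numbers stand for stronger inhibition and higher numbers for weaker inhibition), reads > 15000 nM; this is a limit of the assay, not a number.
Compound 2, `COc1nc(N)nc2c1c(-c1ccoc1)cn2[C@@H]1O[C@H](CO)[C@@H](O)[C@H]1O`, in this assay reads > 20000 nM; again a limit.
Compound 3, `Cc1nc(N)c2c(-c3ccoc3)cn([C@@H]3O[C@H](CO)[C@@H](O)[C@H]3O)c2n1`, in this assay reads > 20000 nM; also a limit.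

Compound 3 therefore stands at the limit of > 20000 nM in this assay, at which 2 of the 3 values shown sit, and no number is known for it. For the measured compounds named here, the two further values shown are likewise limits, one at the limit of > 15000 nM in this assay, at which 1 of the 3 values shown sits, and one at the limit of > 20000 nM in this assay, at which 2 of the 3 values shown sit, so nothing in the measured set separates one compound from another, and no step between measured compounds can be drawn or sized.

The untested compound 4, `Nc1nc(N)c2c(-c3ccoc3)cn([C@@H]3O[C@H](CO)[C@@H](O)[C@H]3O)c2n1`, differs from compound 3 by amino in place of methyl on an aromatic carbon. Going by the values given here, with every measured value a limit, there is no measured step on which to judge the size or direction of this change, and compound 1, which carries amino at the same place, also sits at a limit.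

For this assay the expectation is a step of no clear direction beyond the scatter, with compound 4 remaining near the limit; a number no higher from compound 3 to compound 4 (the limit leaves the size open) is the estimated step. Compound 4 is expected to read about 20000 nM, within 5000 nM to 60000 nM, most likely once more as a limit rather than a number.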

Compound 4, half-maximal inhibitory concentration: > 20000 nM
Compound 4: a limit, no number; the forecaster's own chance of this, stated with the estimate: 75%; the middle value lies on the limit itself.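

In this assay compound 4 gives > 20000 nM, a limit and not a number. For the compounds shown here, compound 1, compound 2 and compound 3 also stand at limits, so no step from any of them to compound 4 can be read. The compounds shown leave open whether amino, methyl, methoxy, phenyl or furan-3-yl makes any difference to this read-out.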